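A few compounds are considered here, and "the series" means these few. Any claim that something is new, unique, unknown or untested is made for them only; others in the source may bear on it.

Measured compounds:
compound 1 `CC[C@@H]1C(=O)N(C)c2cnc(-n3ccc4cc(F)ccc43)nc2N1C1CCCC1` gives 16000 nM in a functional assay on Huh-7 cells (Homo sapiens) for antiproliferative activity, read by CCK-8 assay, with a stated time of 72 h; on this read-out lower numbers stand for stronger inhibition of growth and higher numbers for weaker inhibition of growth
compound 2 `CCC1C(=O)N(C)c2cnc(-n3ccc4cc(C(=O)NC)ccc43)nc2N1c1ccn(C)n1` gives 13200 nM in this assay
compound 3 `CCNC(=O)c1ccc2c(ccn2-c2ncc3c(n2)N(C2CCCC2)[C@H](CC)C(=O)N3C)c1` gives 596 nM in this assay

Compound 2 stands second highest of the three numbers; its gap to compound 1 is within the scatter, while compound 3 lies well beyond it with the lowest number. For the measured compounds named here, the only measured step between single-change neighbours is a 27-fold lower number from compound 1 to compound 3 (1.43 log units; beyond the scatter), a large drop that comes from replacing fluoro on an aromatic carbon with ethylcarbamoyl; it concerns the presence of the carbamoyl group itself, not the substituent on its nitrogen.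

Compound 4 `CCC1C(=O)N(C)c2cnc(-n3ccc4cc(C(=O)NC5CCCC5)ccc43)nc2N1c1ccn(C)n1` differs from compound 2 by cyclopentyl in place of methyl on an amide-type nitrogen. Going by the values given here, no measured pair in this set varies the group on the amide-type nitrogen, so the series gives no direct guide to the size or direction of this change. The carbamoyl group is already present in compound 2, and the step from compound 1 to compound 3 does not transfer to a change further out on that group. The step is therefore expected to be a 1.3-fold lower number from compound 2 to compound 4 (0.12 log units; within the scatter), with no movement beyond the scatter anticipated. Compound 4 is estimated to give 10000 nM (range 3000 nM to 35000 nM) in this assay.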

Compound 4, concentration for 50% growth inhibition: "not active" (no number reported)
Compound 4: no number reported; there is nothing to compare the estimate with.
By their numbers in this assay, from the lowest: compound 3; then compounds 2 and 1 (each within the scatter of the next).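

For the compounds shown here, compound 4 is reported only as "not active" in this assay, without a number, and no step from compound 2 to compound 4 can be read. The compounds shown leave open how methylcarbamoyl and cyclopentylcarbamoyl compare on this read-out. No supporting data bear on this result.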